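Piperidine Replaces an Open-Chain Amine on the Shared Core

The source may report more compounds than this note shows. Statements on the series, on what has been measured and on what is new or still open speak of the compounds shown alone.

Compound 1, `C=C(C)CN(CC)Cc1c(C(F)(F)F)nc2n(-c3c(C)cc(C)cc3C)c(Cl)cn12`: 67 nM
Compound 2, `CCN(Cc1ccc(Cl)c(Cl)c1)Cc1c(C(F)(F)F)nc2n(-c3c(C)cc(C)cc3C)c(Cl)cn12`: 580 nM
Compound 3, `Cc1cc(C)c(-n2c(Cl)cn3c(CN4CCCC4Cc4ccccc4)c(C(F)(F)F)nc23)c(C)c1`: 190 nM

All three were measured in an assay on cells for displacement of a labelled ligand from corticotropin-releasing factor receptor 1 (Homo sapiens), with a stated time of 100 min; on this read-out higher numbers stand for weaker inhibition and lower numbers for stronger inhibition. Compound 1 gives the lowest number of the three, with compound 3 and then compound 2 standing higher. Within the data shown here, the only single-change step available is an 8.7-fold higher number from compound 1 to compound 2 (0.94 log units; beyond the scatter). Compound 4, `Cc1cc(C)c(-n2c(Cl)cn3c(CN4CCCCC4)c(C(F)(F)F)nc23)c(C)c1`, carries piperidin-1-yl in place of ethyl(2-methylprop-2-en-1-yl)amino on a saturated chain carbon bound to an aromatic carbon. Here the amine nitrogen becomes part of a ring rather than gaining a larger substituent, so the measured step bears only loosely on this change, and no measured pair closes an open chain into a ring. A modest weakening is therefore expected, a 2.2-fold higher number from compound 1 to compound 4 (0.35 log units; beyond the scatter), though it may stay within the usual scatter. Compound 4 is expected to give 150 nM (range 40 nM to 550 nM).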

Compound 4, inhibition constant: 1200 nM
Beside the measured number, compound 4's estimate is 8.0-fold (0.90 log units) below it, outside the stated range (above it).
By their numbers in this assay, from the lowest: compound 1; then compound 3; then compound 2; then compound 4.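

At this position, closing the open-chain amine into piperidin-1-yl gives an 18-fold higher number from compound 1 to compound 4 (1.25 log units; beyond the scatter) in this assay. A large loss here therefore needs no added bulky group like the 3,4-dichlorophenyl of compound 2, as the entering group has fewer heavy atoms than the one it replaces. Nothing available explains this loss.

From the compounds shown here alone, the ring and the loss of the double bond arrive together in this change, so their separate contributions remain open. Also open, going by these compounds, is how diethylamino, an open chain without that double bond, would stand here.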